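Replacing 2-methyl-1,3-thiazol-4-yl with pyrazin-2-yl in compound 3

The source may report more compounds than this note shows. Statements on the series, on what has been measured and on what is new or still open speak of the compounds shown alone.

Of the compounds shown here, three have so far been tested in an in vivo ADME assay on the whole organism (strain 129/SvEvBrd x C57BL/6) for pharmacokinetics, with Mus musculus as the target; on this read-out higher numbers stand for higher oral bioavailability and lower numbers for lower oral bioavailability. Compound 1 (`CC(=O)c1ncc([C@@H](O)[C@H](O)[C@H](O)CO)s1`) gives 65%, compound 2 (`CC(=O)c1nc([C@@H](O)[C@H](O)[C@H](O)CO)c(C)[nH]1`) gives 11%, and compound 3 (`Cc1nc(-c2nc([C@@H](O)[C@H](O)[C@H](O)CO)c[nH]2)cs1`) gives 23%. Compound 3 therefore holds the middle place of the three. Its number is higher than that of compound 2 and lower than that of compound 1, and both gaps are beyond the usual scatter of repeated measurements.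

Compound 4 (`OC[C@@H](O)[C@@H](O)[C@H](O)c1c[nH]c(-c2cnccn2)n1`) has not yet been measured. It differs from compound 3 in one place, with pyrazin-2-yl in place of 2-methyl-1,3-thiazol-4-yl on an aromatic carbon. For the measured compounds named here, no pair of measured compounds differs in only one place, so the data give no direct guide to the size or direction of such a change. The best starting point is therefore the value of compound 3 itself, and no shift beyond the scatter is expected. The expected change is a number 1 percentage points lower from compound 3 to compound 4 (within the scatter). For compound 4 the estimate is 22%, with an expected range of 8% to 42%.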

Compound 4, oral bioavailability: 10%
Compound 4: middle estimate off by 12 percentage points, on the high side; measured number inside the range.
By their numbers in this assay, from the lowest: compounds 4 and 2 (each within the scatter of the next); then compound 3; then compound 1.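

In this assay, exchanging one aromatic ring for another at this position gives a number 13 percentage points lower from compound 3 to compound 4 (beyond the scatter), so the group on this aromatic carbon between two ring nitrogen atoms does affect the read-out. The two groups have the same counts of heavy atoms, hydrogen-bond donors and acceptors, and neither carries a net charge, so matching these counts does not keep the number unchanged in this pair; they differ in ring size and in having sulfur or a second nitrogen. Nothing measured here explains the lower number.

As far as these compounds go, it remains open how an unsubstituted phenyl ring, an amine or a carboxylic acid at this position would compare with these two groups. From the compounds shown here alone, it is also open whether the same exchange would give a similar step on a different core.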